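The compounds below may be only part of what the source reports. "The series", "measured", "known", "first", "only" and "open" are said of these compounds alone.

Measured:
compound 1 `Cc1ccc(C(=O)Nc2cccc(OC(F)(F)F)c2)cc1C#Cc1cc(-c2cnn(C)c2)cnc1N`: 33.7 nM
compound 2 `COc1cc(NC(=O)c2ccc(C)c(C#Cc3cc(-c4cnn(C)c4)cnc3N)c2)cc(OC)c1OC`: 2.9 nM

Among the compounds with values here, compound 2 gives the lowest number of the two in an ADME assay on RBL-2H3 cells (Rattus norvegicus) for cytotoxicity, read by CCK-8 assay, with a stated time of 24 h; on this read-out lower numbers stand for higher toxicity in this test and higher numbers for lower toxicity in this test; the one step measured, a 12-fold lower number from compound 1 to compound 2 (1.07 log units; beyond the scatter), is large and beyond the scatter. Compound 3 `Cc1ccc(C(=O)Nc2ccc(Cl)c(C(F)(F)F)c2)cc1C#Cc1cc(-c2cnn(C)c2)cnc1N` differs from compound 2 by 4-chloro-3-(trifluoromethyl)phenyl in place of 3,4,5-trimethoxyphenyl on an amide-type nitrogen. Within the data shown here, the new group has no hydrogen-bond acceptors, like the group of compound 1, so the only step that bears on it runs the other way. For compound 3 the expected step is a 6.9-fold higher number from compound 2 to compound 3 (0.84 log units; beyond the scatter), a higher number, though the new group is not identical to that of compound 1. The estimate for compound 3 in this assay is 20 nM (5 nM to 80 nM).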

Compound 3, half-maximal cytotoxic concentration: 21 nM
Compound 3: the middle estimate sits 1.1-fold (0.02 log units) below what was measured, within the range that was stated.
By their numbers in this assay, from the lowest: compound 2; then compounds 3 and 1 (each within the scatter of the next).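

At the amide-type nitrogen, this assay shows a 7.2-fold higher number from compound 2 to compound 3 (0.86 log units; beyond the scatter), so the number of compound 2 does not carry over to the 4-chloro-3-(trifluoromethyl)phenyl group. Exchanging 3-(trifluoromethoxy)phenyl for that group gives a 1.6-fold lower number from compound 1 to compound 3 (0.21 log units; within the scatter), so among these three compounds only the 3,4,5-trimethoxyphenyl group stands apart from the other two. No measurement available here accounts for these differences.

As far as these compounds go, it remains open whether a single methoxy group on the phenyl ring would give a number like that of compound 2. From the compounds shown here alone, the effect of an amine or a carboxylic acid on that ring also remains open.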